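The compounds below may be only part of what the source reports. "The series", "measured", "known", "first", "only" and "open" are said of these compounds alone.

Compound 2 `CC(C(=O)NCc1cc(C(F)(F)F)nn1-c1ccc(F)c(F)c1)c1ccc2c(c1)CCC2` gives 30.5 nM in an assay on CHO-K1 cells for antagonist activity at transient receptor potential cation channel subfamily V member 1 (Homo sapiens), read by FLIPR (a lower number here means a stronger inhibitor, a higher number a weaker inhibitor), and of the two numbers shown it stands at one end, with compound 1 `CC(C(=O)NCc1cc(C(F)(F)F)nn1-c1ccc(Cl)cc1)c1ccc2c(c1)CCC2` nearest at 45 nM; the step of a 1.5-fold lower number from compound 1 to compound 2 (0.17 log units; within the scatter) lies within the scatter. Compound 3 `CC(C(=O)NCc1cc(C(F)(F)F)nn1-c1ccc(F)c(Cl)c1)c1ccc2c(c1)CCC2` differs from compound 2 by chloro in place of fluoro on an aromatic carbon. Among the compounds with values here, the only measured step that bears on this, a 1.5-fold lower number from compound 1 to compound 2 (0.17 log units; within the scatter), was within the scatter, so in this assay no step beyond the scatter is expected, in either direction. Compound 3 is therefore estimated at 30 nM, with a range from 12 nM to 75 nM, an expected step of a 1.0-fold lower number from compound 2 to compound 3 (0.01 log units; within the scatter).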

Compound 3, inhibition constant: 14.7 nM
Estimate against measurement, compound 3: 2.0-fold (0.31 log units) above; the measured number falls inside the stated range.
By their numbers in this assay, from the lowest: compound 3; then compounds 2 and 1 (each within the scatter of the next).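

In this assay, within the data shown here, chloro in place of fluoro on this aromatic carbon, ortho to a fluoro group, gives a 2.1-fold lower number from compound 2 to compound 3 (0.32 log units; beyond the scatter) and so is the first single change here to move the number beyond the scatter. The 3-chloro-4-fluorophenyl group also separates from the 4-chlorophenyl group, with a 3.1-fold lower number from compound 1 to compound 3 (0.49 log units; beyond the scatter) as the step between them. Nothing available gives a reason for either step.

As far as these compounds go, how a bromo, methyl or methoxy group would read on this same carbon stays open, so it cannot be said whether the trend runs past chloro.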